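A few compounds are considered here, and "the series" means these few. Any claim that something is new, unique, unknown or untested is made for them only; others in the source may bear on it.

Working notes on the series. Going by the values given here, compound 1 `CC(=O)Nc1ccc(Nc2nccc(-c3cccnc3)n2)cc1` in a functional assay for inhibition, with Homo sapiens as the target (a higher number here means a weaker inhibitor, a lower number a stronger inhibitor), gives 3600 nM, the highest of the two numbers so far; the nearest is compound 3 `CC1CCN(c2ccc(Nc3nccc(-c4cccs4)n3)cc2)CC1` at 400 nM, which differs from compound 1 at more than one place. Compound 2 `CN(c1ccccc1)c1nccc(-c2ccncc2)n1` returns only a limit of the assay, > 24000 nM, as stated in the limit of > 24000 nM in this assay, at which 1 of the 3 values shown sits, and no number. The step to be followed leads from compound 1 to compound 4 `c1cncc(-c2ccnc(Nc3ccc(-n4ccnc4)cc3)n2)c1`: 1H-imidazol-1-yl in place of acetamido on an aromatic carbon. Among the compounds with values here, since no measured pair differs in one place alone, the size of this change can only be guessed. Compound 3 shows that a ring-bearing group on this aromatic carbon can go with a lower number, but its other change makes the comparison inconclusive. A modest lowering is expected, a 1.8-fold lower number from compound 1 to compound 4 (0.26 log units; within the scatter), of a size near the scatter. For compound 4 the estimated value in this assay is 2000 nM, with a range from 500 nM to 8000 nM.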

Compound 4, half-maximal inhibitory concentration: 1300 nM
Compound 4: middle estimate off by 1.5-fold (0.19 log units), on the high side; low and high end bracket the measured number.
By their numbers in this assay, from the lowest: compound 3; then compound 4; then compound 1. At a limit, above all of these: compound 2.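

In this assay, going by these compounds alone, this gives the first step that can be read at this position: a 2.8-fold lower number from compound 1 to compound 4 (0.44 log units; beyond the scatter), so the aromatic carbon para to a large group accepts 1H-imidazol-1-yl in place of acetamido, and the number falls beyond the scatter. The entering group has one five-membered aromatic ring and 0 hydrogen-bond donors, so compound 4 shows that a hydrogen-bond donor in this group is not required for a number in this range. The compounds shown give no measured basis for a cause of this step.

Going by these compounds, whether the lowering follows from the added ring or from the loss of the acetamido group stays open, as one step cannot separate the two. On these data alone, how a simple amine, a carboxylic acid or a morpholine ring would compare on this aromatic carbon of the shared core also remains open.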